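A few compounds are considered here, and "the series" means these few. Any claim that something is new, unique, unknown or untested is made for them only; others in the source may bear on it.

Compound 3 `Nc1ccc(Nc2c(C(=O)NCc3ccc(F)cc3)nc(Br)c3cccnc23)cc1` is tested in a functional assay on HCT-116 cells (Homo sapiens) for cytotoxicity, read by MTT assay, with a stated time of 72 h (a lower number here means a stronger inhibitor, a higher number a weaker inhibitor), where compound 3 gives 10000 nM. Among the compounds with values here, of the two numbers recorded it is the higher one; compound 2 `N[C@H]1CC[C@H](Nc2c(C(=O)NCc3ccc(Cl)cc3)nc(Br)c3cccnc23)CC1` gives 4000 nM, but it differs from compound 3 in more than one place, so no single step links them. Compound 1 `O=C(NCc1ccc(F)cc1)c1nc(Br)c2cccnc2c1NCc1ccccc1` reaches only a limit of this assay, > 20000 nM; one of the three values sits at that limit (the limit of > 20000 nM in this assay, at which 1 of the 3 values shown sits). Compound 4 `NCCNc1c(C(=O)NCc2ccc(F)cc2)nc(Br)c2cccnc12` is the next compound, and its change from compound 3 is 2-aminoethyl in place of 4-aminophenyl on a nitrogen on an aromatic ring. Within the data shown here, only one measured step exists, an at least 2.0-fold lower number from compound 1 to compound 3 (0.30 log units; that floor lies within the scatter), and it introduces the 4-aminophenyl rather than exchanging it, so it gives little direct guidance on the present change. The expected step from compound 3 to compound 4 is therefore modest, a 2.0-fold lower number from compound 3 to compound 4 (0.30 log units; within the scatter), leaning toward a lower number, with wide uncertainty. Compound 4 is estimated at 5000 nM, within a range from 1500 nM to 20000 nM.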

Compound 4, half-maximal inhibitory concentration: > 20000 nM
Compound 4: only a limit was reported; the forecaster's own chance of this, stated with the estimate: 20%; middle value at least 4.0-fold (0.60 log units) from the limit.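

In this assay, within the data shown here, the exchange of 4-aminophenyl for 2-aminoethyl on this nitrogen gives an at least 2.0-fold higher number from compound 3 to compound 4 (0.30 log units; that floor lies within the scatter) and is the first measured exchange at this position, though its floor alone does not pass the scatter. Compound 4 is reported only as a limit, as is compound 1, so the step between those two cannot be read: the limit of > 20000 nM in this assay, at which 2 of the 4 values shown sit. An amine on the group is thus not enough by itself to give a number short of the limit, since compound 3 gives one and compound 4 does not.

Going by these compounds, whether a longer chain ending in an amine, or a phenyl ring without its amine, would give a number remains open. Compound 2 differs from compound 3 in more than one place, so it cannot settle the role of the ring.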